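Notes on the step from compound 2 to compound 4

The source may report more compounds than this note shows. Statements on the series, on what has been measured and on what is new or still open speak of the compounds shown alone.

Compound 1 `O=C(O)CCC(=O)OCCCCCCSc1ccc([N+](=O)[O-])c2nonc12` gives 3640 nM in a functional assay on A549 cells (Homo sapiens) for inhibition, read by MTT assay, with a stated time of 72 h; on this read-out lower numbers stand for stronger inhibition and higher numbers for weaker inhibition. Compound 2 `O=C(CCC(=O)OCCCCCCSc1ccc([N+](=O)[O-])c2nonc12)Nc1ccccc1` gives 1960 nM, the lowest of the three numbers, and compound 3 `Cc1ccc(NC(=O)CCC(=O)OCCCCCCSc2ccc([N+](=O)[O-])c3nonc23)cc1` gives 5240 nM. The measured steps at the amide end are all small: a 1.9-fold lower number from compound 1 to compound 2 (0.27 log units; within the scatter), a 1.4-fold higher number from compound 1 to compound 3 (0.16 log units; within the scatter), and a 2.7-fold higher number from compound 2 to compound 3 (0.43 log units; beyond the scatter). Compound 4 `O=C(CCC(=O)OCCCCCCSc1ccc([N+](=O)[O-])c2nonc12)NCCN1CCCC1` differs from compound 2 by 2-(pyrrolidin-1-yl)ethyl in place of phenyl on an amide-type nitrogen. Going by the values given here, no measured step exchanges the phenyl for a chain bearing a ring; the changes seen at this nitrogen moved the number only modestly, so a step of similar size in this assay, direction uncertain, is expected, a 1.3-fold higher number from compound 2 to compound 4 (0.12 log units; within the scatter). Compound 4 is therefore estimated at 2600 nM, with a range of 900 nM to 7500 nM.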

Compound 4, half-maximal inhibitory concentration: 3240 nM
Estimate against measurement, compound 4: 1.2-fold (0.10 log units) below, and the stated range covers the measured number.
By their numbers in this assay, from the lowest: compounds 2, 4, 1 and 3 (each within the scatter of the next, the first and the last beyond it).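

In this assay, 2-(pyrrolidin-1-yl)ethyl on the amide-type nitrogen gives a 1.7-fold higher number from compound 2 to compound 4 (0.22 log units; within the scatter) in place of phenyl and a 1.6-fold lower number from compound 3 to compound 4 (0.21 log units; within the scatter) in place of 4-methylphenyl, so an aromatic ring on this nitrogen is not required to keep the number in this range. With a 1.1-fold lower number from compound 1 to compound 4 (0.05 log units; within the scatter) for (2-(pyrrolidin-1-yl)ethyl)amino in place of hydroxy, the new group also stays within the scatter of the carboxylic acid. Nothing available explains these small steps. On these data alone, whether a morpholine ring or a longer chain before the pyrrolidine ring would behave the same remains open. As far as these compounds go, a simple primary amine at the chain end is equally open.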